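The compounds below may be only part of what the source reports. "The series", "measured", "known", "first", "only" and "open" are said of these compounds alone.

Three compounds share one core, and they differ only in the groups hung on it. Compound 1 `CCCC1=C(C(=O)OCC)C(c2cccc([N+](=O)[O-])c2)C(C(=O)OCC)=C(C)N1` gives, in a functional assay on HEK293 cells for antagonist activity at Voltage-dependent L-type calcium channel subunit alpha-1D (Rattus norvegicus), read by FLIPR (on this read-out higher numbers stand for weaker inhibition and lower numbers for stronger inhibition), a value of 105 nM. Compound 2 `CCCCCOC(=O)C1=C(C)NC(C)=C(C(=O)OCC)C1c1cccc([N+](=O)[O-])c1` gives in this assay a value of 130 nM. Compound 3 `COC(=O)C1=C(C)NC(C)=C(C(=O)OCc2ccccc2)C1c1cccc([N+](=O)[O-])c1` gives in this assay a value of 15 nM, the lowest number of the three; its gaps to compound 1 and to compound 2 both lie beyond the usual scatter of repeated measurements, so compound 3 is the strongest inhibitor among these three.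

Compound 4 `COC(=O)C1=C(C)NC(C)=C(C(=O)OCCOCc2ccccc2)C1c1cccc([N+](=O)[O-])c1` is the next compound, and it differs from compound 3 in one place: (benzyloxy)methyl in place of phenyl on a saturated chain carbon bound to an oxygen next to a carbonyl group. The single six-membered aromatic ring of carbon only is kept, but it is now reached through a longer link that brings in one hydrogen-bond acceptor. For the measured compounds named here, no pair of measured compounds shows a change of this kind, so any expectation rests only on the spread seen so far and on the fact that compound 3 already sits at the low end. The step is estimated as a 2.0-fold higher number from compound 3 to compound 4 (0.30 log units; within the scatter), a mild weakening that could well stay within the scatter. For compound 4 the estimated value in this assay is 30 nM, with a range from 8 nM to 120 nM.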

Compound 4, half-maximal inhibitory concentration: 12 nM
Estimate against measurement, compound 4: 2.5-fold (0.40 log units) above; measured number inside the range.
By their numbers in this assay, from the lowest: compounds 4 and 3 (each within the scatter of the next); then compounds 1 and 2 (each within the scatter of the next).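

In this assay, putting (benzyloxy)methyl in place of phenyl on a saturated chain carbon bound to an oxygen next to a carbonyl group gives a 1.3-fold lower number from compound 3 to compound 4 (0.10 log units; within the scatter) and so leaves the two compounds indistinguishable on this read-out. Read one bond further out, this is benzyl giving way to 2-(benzyloxy)ethyl: the six-membered aromatic ring is kept but reached through a longer link, and the group grows from 6 to 9 heavy atoms and gains one hydrogen-bond acceptor, yet the two numbers stay within the scatter of each other, so at this place the link to the ring can be lengthened in this way without a measurable penalty. Nothing given here explains why the longer link is accepted.

The compounds shown leave open whether the aromatic ring at the end of the chain matters at all, since a plain longer chain such as hexyl, with no ring, would test that directly. They also leave open how this place responds to a chain ending in an amine or a carboxylic acid instead of a benzyl ether.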